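The source may report more compounds than this note shows. Statements on the series, on what has been measured and on what is new or still open speak of the compounds shown alone.

Working notes on the amide series

The three measured compounds share one core and differ only in the amide attached to the saturated ring. Compound 1 `CC(C)c1ccc(NC(=O)[C@H]2CN(C)C[C@@H]2c2ccc(/C=C/C(=O)Nc3ccccc3N)cc2)cc1` gives 54 mL/min/kg in an in vitro ADME assay on microsomes from liver (Mus musculus) for pharmacokinetics, read by LC-MS, with a stated time of 10 min, tested at 1 uM; a lower number here means slower removal, a higher number faster removal of the compound. Compound 2 `CN1C[C@H](C(=O)Nc2ccc(C(F)(F)F)cc2)[C@@H](c2ccc(/C=C/C(=O)Nc3ccccc3N)cc2)C1` gives 23 mL/min/kg in this assay, and compound 3 `CN1C[C@H](C(=O)NC2CC2)[C@@H](c2ccc(/C=C/C(=O)Nc3ccccc3N)cc2)C1` gives 7 mL/min/kg. Compound 2 therefore stands second highest of the three numbers: compound 1 is nearest (a 2.3-fold lower number from compound 1 to compound 2 (0.37 log units; beyond the scatter)) and compound 3 furthest (a 3.3-fold lower number from compound 2 to compound 3 (0.52 log units; beyond the scatter)).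

Compound 4 `CN1C[C@H](C(=O)N2CCCCC2)[C@@H](c2ccc(/C=C/C(=O)Nc3ccccc3N)cc2)C1` is not yet measured. It differs from compound 2 in one place: piperidin-1-yl in place of (4-(trifluoromethyl)phenyl)amino on a carbonyl carbon. Within the data shown here, the steps that bear on this are those in which an aromatic group on the amide-type nitrogen gave way to a saturated one: a 3.3-fold lower number from compound 2 to compound 3 (0.52 log units; beyond the scatter) and a 7.7-fold lower number from compound 1 to compound 3 (0.89 log units; beyond the scatter). Both point downward and both lie beyond the scatter. Compound 4 likewise gives up the 4-(trifluoromethyl)phenyl of compound 2 for a saturated ring, so a downward step beyond the scatter is expected in this assay; piperidin-1-yl is not cyclopropyl, however, so the full size of the step to compound 3 is not assumed. The expected step is a 2.1-fold lower number from compound 2 to compound 4 (0.32 log units; beyond the scatter). Compound 4 is estimated at 11 mL/min/kg, with a range from 4 mL/min/kg to 28 mL/min/kg.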

Compound 4, clearance: 42 mL/min/kg
For compound 4 the middle estimate is 3.8-fold (0.58 log units) below the measured one, outside the stated range (above it).
By their numbers in this assay, from the lowest: compound 3; then compounds 2, 4 and 1 (each within the scatter of the next, the first and the last beyond it).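

Replacing the aromatic amine on the carbonyl carbon with a saturated ring does not in itself bring the number down in this assay: compound 4, with piperidin-1-yl, stands level with both aromatic amides (a 1.8-fold higher number from compound 2 to compound 4 (0.26 log units; within the scatter); a 1.3-fold lower number from compound 1 to compound 4 (0.11 log units; within the scatter)). Compound 4 therefore goes against the reading that compounds 1, 2 and 3 allowed, and compound 3 is left alone at the low end (a 6.0-fold higher number from compound 3 to compound 4 (0.78 log units; beyond the scatter)), so the low number belongs to cyclopropylamino specifically and not to saturated groups at this position in general. The step from compound 3 to compound 4 changes two things at once, since the ring differs and the amide hydrogen is lost, and it cannot show which of the two counts.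

The compounds shown leave open whether the low number of compound 3 follows the cyclopropyl ring or the amide hydrogen, and a cyclopropyl(methyl)amino or a cyclohexylamino group on this carbonyl carbon would separate the two. No measurement at hand offers a reason for any of these steps.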